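The source may hold more compounds than are shown below. What is called first, only, known or untested is meant among the compounds shown, and "the series" means these compounds.

Compound 1 `O=S(=O)(Nc1cc(-c2cnc3[nH]ncc3c2)cnc1Cl)c1ccccc1` gives 8940 nM in a functional assay on U-87MG ATCC cells for inhibition, with U-87 MG (Homo sapiens) as the target, read by sulforhodamine B assay, with a stated time of 72 h; a higher number here means a weaker inhibitor of growth, a lower number a stronger inhibitor of growth.
Compound 2 `O=S(=O)(Nc1cc(-c2cnc3[nH]nc(-c4ccccc4)c3c2)cnc1Cl)c1ccccc1` reaches only the limit of this assay, > 10000 nM, and no number.
Compound 3 `O=S(=O)(Nc1cc(-c2cnc3[nH]cc(-c4ccncc4)c3c2)cnc1Cl)c1ccccc1` gives 8950 nM in this assay.

Compound 2 therefore stands at the edge of what this assay reports: its value is a limit, the one described by the limit of > 10000 nM in this assay, at which 1 of the 3 values shown sits, and nothing more exact is known of it. The one step that leads to it is an at least 1.1-fold higher number from compound 1 to compound 2 (0.04 log units; that floor lies within the scatter), phenyl in place of hydrogen on an aromatic carbon, a change whose floor lies within the scatter, so it is not shown to have moved growth inhibition at all.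

Compound 4 `O=S(=O)(Nc1cc(-c2cnc3[nH]nc(-c4ccncc4)c3c2)cnc1Cl)c1ccccc1` differs from compound 2 in one place: pyridin-4-yl in place of phenyl on an aromatic carbon. Among the measured compounds shown here, no measured step carries a pyridin-4-yl group onto the core of compound 2. Compound 3 carries that group on a different core, and its value and that of compound 1 lie within the scatter of each other, so neither suggests that the group itself shifts the numbers much. Compound 4 is thus expected to remain near the limit of this assay, with an expected step of a number no higher from compound 2 to compound 4 (the limit leaves the size open). The estimate for compound 4 is 10000 nM, within a range from 4000 nM to 25000 nM.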

Compound 4, concentration for 50% growth inhibition: 3120 nM
Compound 4: the middle estimate sits 3.2-fold (0.51 log units) above what was measured; the whole stated range lies above it.
By their numbers in this assay, from the lowest: compound 4; then compounds 1 and 3 (each within the scatter of the next). At a limit, above all of these: compound 2.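

At this position, on an aromatic carbon of a five-membered aromatic ring with 2 nitrogen, the choice of ring now matters in this assay: pyridin-4-yl in place of phenyl gives an at least 3.2-fold lower number from compound 2 to compound 4 (0.50 log units; beyond the scatter). The comparison with the core of compound 1 also changes, since pyridin-4-yl in place of hydrogen gives a 2.9-fold lower number from compound 1 to compound 4 (0.46 log units; beyond the scatter), a step beyond the scatter, whereas phenyl in place of hydrogen gives only an at least 1.1-fold higher number from compound 1 to compound 2 (0.04 log units; that floor lies within the scatter), so a group at this position is now shown to be able to strengthen growth inhibition. The step from compound 2 gives a floor rather than a size, as the value of compound 2 is a limit and not a number: the limit of > 10000 nM in this assay, at which 1 of the 4 values shown sits.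

Whether pyridin-3-yl, pyridin-2-yl or a phenyl ring carrying an amine would match pyridin-4-yl at this position remains open, so the compounds shown do not tell how much depends on the ring nitrogen and where it sits. Also open, going by these compounds, is how far growth inhibition can go from here, as compound 4 still gives only 3120 nM.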